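The source may report more compounds than this note shows. Statements on the series, on what has been measured and on what is new or still open speak of the compounds shown alone.

Measured compounds:
compound 1, `Cc1ccc(CNC(=O)c2nc(-c3ccc(F)cc3)n(CC[C@@H](O)C[C@@H](O)CC(=O)O)c2C2CC2)cc1`, with 1.7 nM
compound 2, `O=C(O)C[C@H](O)C[C@H](O)CCn1c(-c2ccc(F)cc2)nc(C(=O)NCc2ccc(F)c(F)c2)c1C1CC1`, with 1.2 nM

In an assay on microsomes from liver for inhibition of 3-hydroxy-3-methylglutaryl-coenzyme A reductase (Rattus norvegicus), read by scintillation counting, with stated times of 0.5 h and 0.75 h (on this read-out lower numbers stand for stronger inhibition and higher numbers for weaker inhibition), compound 2 gives 1.2 nM, and compound 1 gives 1.7 nM, so the two sit within the scatter of each other and neither can be called the stronger inhibitor. Among the measured compounds shown here, the single measured step is a 1.4-fold lower number from compound 1 to compound 2 (0.15 log units; within the scatter), brought by 3,4-difluorophenyl in place of 4-methylphenyl on a saturated chain carbon bound to an amide-type nitrogen.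

Compound 3, `O=C(O)C[C@H](O)C[C@H](O)CCn1c(-c2ccc(F)cc2)nc(C(=O)NCc2cccc(F)c2)c1C1CC1`, is the next member. Its change from compound 2 is hydrogen in place of fluoro on an aromatic carbon; read one bond further out, it is 3,4-difluorobenzyl to 3-fluorobenzyl. For the measured compounds named here, the only step that bears on it is the one from compound 1 to compound 2, which altered the same benzyl ring far more thoroughly and yet stayed within the scatter. Removing one fluoro from that ring is a smaller edit, so no step beyond the scatter is expected in this assay, in either direction.

Compound 3 is therefore estimated at 1.5 nM in this assay, with a range from 0.7 nM to 3.5 nM. The estimate means an expected step of a 1.3-fold higher number from compound 2 to compound 3 (0.10 log units; within the scatter), within the scatter.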

Compound 3, half-maximal inhibitory concentration: 1.2 nM
For compound 3 the middle estimate is 1.3-fold (0.10 log units) above the measured one, and the stated range covers the measured number.
By their numbers in this assay, from the lowest: compounds 2, 3 and 1 (each within the scatter of the next).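

In this assay, taking away only the fluoro para to a large group, ortho to a fluoro group, gives no change at the digits printed from compound 2 to compound 3 (within the scatter), so this one atom on the benzyl ring can be read on its own, which the earlier pair could not offer, as it exchanged the whole substitution of that ring at once. The second comparison, a 1.4-fold lower number from compound 1 to compound 3 (0.15 log units; within the scatter), shows that the 3-fluorobenzyl amide also stays within the scatter of the 4-methylbenzyl amide, so the three benzyl rings shown do not separate on this read-out, and neither the 3,4-difluoro nor the 3-fluoro ring can be ranked against the 4-methyl ring. No measurement at hand accounts for this closeness of the three numbers.

As far as these compounds go, what stays open is whether the remaining fluoro counts for anything, which a plain benzyl group with hydrogen in its place would test, and whether a methoxy group, an amine or a carboxylic acid on the same ring would stay as close. All three numbers also come from one assay, so whether the same closeness holds on any other read-out cannot be said from these compounds.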